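Shortening the Side Chain of an Amino Hydroxamate

The compounds below may be only part of what the source reports. "The series", "measured", "known", "first", "only" and "open" are said of these compounds alone.

Compound 1 `N=C(N)NCCC[C@H](N)C(=O)NO` carries a hydroxamic acid on a carbon that also bears an amine and a chain ending in a guanidine. In an assay on isolated protein for inhibition of tyrosine-protein kinase CSK (Homo sapiens), tested at 25 uM, in the presence of a further agent that is not named here (on this read-out lower numbers stand for less inhibition and higher numbers for more inhibition at the one concentration tested (going by the name of the read-out)), compound 1 gives 0%. Compound 2 `CCCC(N)C(=O)NO` keeps the amine and the hydroxamic acid but carries a propyl group instead of the longer chain. In this assay compound 2 gives 0%, level with compound 1 at the digits shown, and the two values lie within the usual scatter of each other, so nothing can be read from that pair. Compound 3 `NCC(=O)NO` is the smallest member of the set. It differs from compound 2 by hydrogen in place of propyl on a saturated chain carbon bound to an amine nitrogen and a carbonyl carbon. Among the compounds with values here, no measured pair in this set shows what removing a propyl group does, and both measured compounds show no inhibition at the concentration tested. The step expected here is therefore no change at the digits printed from compound 2 to compound 3 (within the scatter), nothing beyond the scatter. Compound 3 is expected to give 0% in this assay, with a range from -5% to 10%.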

Compound 3, a percentage reported as inhibition, at one concentration (the size of the read-out at that concentration, not a potency): 0%
Compound 3: the middle estimate sits on the measured number at the digits printed; measured number inside the range.
By their numbers in this assay, from the lowest: compounds 1, 2 and 3 (each within the scatter of the next).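

In this assay, within the data shown here, the step gives the first direct reading at this position: hydrogen in place of propyl on a saturated chain carbon bound to an amine nitrogen and a carbonyl carbon brings no change at the digits printed from compound 2 to compound 3 (within the scatter) and thus nothing beyond the scatter. With compound 3 at 0%, taking off the propyl group leaves no measurable trace in this read-out, so hydrogen and propyl cannot be told apart here at the one concentration tested. Nothing measured here offers an explanation for this flat result.

All three compounds print the same reading, which leaves open whether any group on this carbon can produce inhibition in this read-out, or whether the amine and hydroxamic acid they share can support any inhibition at all. Whether a carboxylic acid on this carbon, or a longer chain ending in an amine, would give a reading beyond the scatter cannot be told from the compounds shown.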